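The source may hold more compounds than are shown below. What is called first, only, known or untested is meant among the compounds shown, and "the series" means these compounds.

Measured so far:
Compound 1: `CC(C)(C)C(NC(=O)c1ccc(Cl)cc1)N/C(=N/c1cccnc1)NC#N` with 6310 nM in a functional assay with sulfonylurea receptor 2, Kir6.2 (Homo sapiens) as the target; a lower number here means that less compound is needed, a higher number that more compound is needed for the effect.
Compound 2: `CC(C)(C)C(NC(=O)c1ccc(Cl)cc1)N/C(=N/c1cccnc1)N[N+](=O)[O-]` with 31600 nM.

Both compounds share one core and differ only in the group carried on one amine nitrogen. Replacing cyano with nitro gave a 5.0-fold higher number from compound 1 to compound 2 (0.70 log units; beyond the scatter), a modest weakening. Going by the values given here, compound 2 therefore stands at the highest number of the two, with compound 1 as its only neighbour at a clearly lower value.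

Compound 3, `CC(C)(C)C(NC(=O)c1ccc(Cl)cc1)N/C(=N/c1cccnc1)NS(N)(=O)=O`, takes the next step on the same nitrogen: sulfamoyl in place of nitro on an amine nitrogen. Among the compounds with values here, only one measured step bears on this position, and it shows that swapping the group on this nitrogen shifts the number by a modest, clearly resolved amount rather than leaving it untouched. Sulfamoyl is a third, untested option here, so its direction cannot be read from the cyano-to-nitro step alone. Given that the nitro compound sits at the weak end, an estimated step of a 2.1-fold lower number from compound 2 to compound 3 (0.32 log units; beyond the scatter) back toward the cyano compound seems reasonable. Compound 3 is thus expected to give about 15000 nM in this assay, plausibly between 4000 nM and 60000 nM.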

Compound 3, half-maximal effective concentration: < 100000 nM
Compound 3: no number, only a limit; the forecaster's own chance of this, stated with the estimate: 15%; the middle value does not contradict the limit.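

In this assay compound 3 gives < 100000 nM, which is a limit of the assay and not a number. Going by these compounds alone, no step from compound 1 or compound 2 to compound 3 can be read from it. The compounds shown leave open whether sulfamoyl on this amine nitrogen gives a higher or lower number than cyano or nitro.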